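Thiophene to methyl-isoxazole swap on the aminopyrazinone series

A few compounds are considered here, and "the series" means these few. Any claim that something is new, unique, unknown or untested is made for them only; others in the source may bear on it.

Measured so far in an assay for inhibition of Caspase-8 (Homo sapiens); a lower number here means a stronger inhibitor, a higher number a weaker inhibitor:

compound 1 `CC[C@@H](C(=O)N[C@@H](CC(=O)O)C(=O)CSCc1ccccc1)n1cccc(NC(=O)[C@H](CC(=O)O)NC(C)=O)c1=O`: 220 nM
compound 2 `CCC(C(=O)N[C@@H](CC(=O)O)C(=O)CSCc1ccccc1)n1ccnc(NCc2cccs2)c1=O`: 2090 nM
compound 3 `CCC(C(=O)N[C@@H](CC(=O)O)C(=O)CNCN1CCC(Cc2ccccc2)CC1)n1ccnc(NCc2nonc2C)c1=O`: 6020 nM

Compound 2 stands second highest of the three numbers. Its nearest neighbour is compound 3, whose value is higher by an amount beyond the usual scatter; the furthest is compound 1, whose value is lower, also beyond the scatter. Among the measured compounds shown here, none of these pairs differs in a single place, so no step between measured compounds is at hand, and the three values are taken only as they stand.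

Compound 4 `CCC(C(=O)N[C@@H](CC(=O)O)C(=O)CSCc1ccccc1)n1ccnc(NCc2cc(C)no2)c1=O` is not yet measured. It differs from compound 2 in one place: 3-methyl-1,2-oxazol-5-yl in place of thiophen-2-yl on a saturated chain carbon bound to a nitrogen on an aromatic ring. Everything else, including the thioether ketone side and the shared core, is kept.

For the measured compounds named here, with no single-place step available among compounds 1, 2 and 3, there is nothing to set either direction or size for this exchange. The expectation is therefore a step in this assay of no clear size beyond the scatter, kept close to compound 2, with the width of the estimate reflecting that lack of precedent. For compound 4 the estimate in this assay is 2800 nM, in the range 900 nM to 9000 nM, which corresponds to an expected step of a 1.3-fold higher number from compound 2 to compound 4 (0.13 log units; within the scatter).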

Compound 4, half-maximal inhibitory concentration: 3300 nM
Beside the measured number, compound 4's estimate is 1.2-fold (0.07 log units) below it; the range from low to high includes it.
By their numbers in this assay, from the lowest: compound 1; then compounds 2, 4 and 3 (each within the scatter of the next, the first and the last beyond it).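

In this assay, among the compounds shown here, the exchange of thiophen-2-yl for 3-methyl-1,2-oxazol-5-yl on a saturated chain carbon bound to a nitrogen on an aromatic ring gives a 1.6-fold higher number from compound 2 to compound 4 (0.20 log units; within the scatter), the only single-place step available so far. At this position, with the thioether ketone side and the shared core kept, the assay therefore does not separate a five-membered aromatic ring with 1 hetero atom from a methyl-bearing one with 2 hetero atoms, so this one exchange is tolerated, although a single pair sets no rule for the position. No measured evidence accompanies this step that could account for the result.

Going by these compounds, the step covers only these two aromatic rings, so it remains open whether a carboxylic acid or a primary amine in place of the ring, or a longer chain in place of the single saturated chain carbon, would give a step beyond the scatter. Also open, on these data alone, is whether the same exchange would give a comparable step with a different group on the ketone side of the molecule.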